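The source may hold more compounds than are shown below. What is called first, only, known or untested is meant among the compounds shown, and "the series" means these compounds.

Compounds measured in a functional assay on KG-1 cells (Homo sapiens) for cytotoxicity, read by luminescence and CellTiter-Glo, with a stated time of 3 days; on this read-out higher numbers stand for weaker inhibition and lower numbers for stronger inhibition
Compound 1 `O=C(Nc1cc(C(F)(F)F)cc(C(F)(F)F)c1)c1cc(Br)c(-c2ccccc2)cc1O` gives 300 nM
Compound 2 `O=C(Nc1cc(C(F)(F)F)cc(C(F)(F)F)c1)c1ccc(-c2ccccc2)cc1O` gives 860 nM

Compound 2 has the higher of these two numbers, which makes it the weaker inhibitor of the pair in this assay. Among the compounds with values here, the only measured step, a 2.9-fold higher number from compound 1 to compound 2 (0.46 log units; beyond the scatter), is a modest one that puts hydrogen in place of bromo on an aromatic carbon.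

The next compound is compound 3 `O=C(Nc1cc(C(F)(F)F)cc(C(F)(F)F)c1)c1ccc(Cl)cc1O`, which differs from compound 2 in one place: chloro in place of phenyl on an aromatic carbon. This is chloro in place of phenyl on an aromatic carbon, meta to a hydroxy group and para to a large group.

The measured step involves neither phenyl nor chloro, so it bears on this change only loosely. Within the data shown here, it shows that one substitution on this core moved the number modestly, but no measurement yet tests the loss of phenyl. A large step is therefore not expected, and no firm direction can be given, so the expectation is for no step beyond the scatter.

The expected change is a 1.2-fold higher number from compound 2 to compound 3 (0.07 log units; within the scatter), an estimate with wide uncertainty.

For compound 3 the estimated value is 1000 nM, with an expected range from 300 nM to 3500 nM.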

Compound 3, half-maximal inhibitory concentration: 620 nM
Beside the measured number, compound 3's estimate is 1.6-fold (0.21 log units) above it; the measured number falls inside the stated range.
By their numbers in this assay, from the lowest: compound 1; then compounds 3 and 2 (each within the scatter of the next).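

In this assay, chloro in place of phenyl gives a 1.4-fold lower number from compound 2 to compound 3 (0.14 log units; within the scatter) and so stays within the usual scatter, even though six heavy atoms and a whole six-membered aromatic ring leave and a single chlorine atom enters. Within the data shown here, the earlier step changed a different place on the shared core, so this is the first evidence on the phenyl itself: in this pair, the phenyl is not needed to keep the number where it stands, and a far smaller group serves as well. No measurement shown here explains why the two compounds read alike, so this is an observation about tolerated change rather than an account of its cause.

Going by these compounds, it remains open whether this place accepts groups of a different kind, such as an amine or a carboxylic acid, or whether the agreement between phenyl and chloro is limited to these two groups. It is also unknown whether bromo in the place it holds in compound 1 would have the same effect on compound 3 as the step between compound 1 and compound 2 suggests.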